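Swapping the pyridyl arm for a hydroxyphenyl group

The compounds below may be only part of what the source reports. "The series", "measured", "known", "first", "only" and "open" are said of these compounds alone.

Compound 1 `CC(Sc1nc2c(cnn2C)c(=O)n1-c1ccc(CCO)cc1)c1ccccc1`: 360 nM
Compound 2 `Cn1ncc2c(=O)n(-c3ccccc3)c(SCc3cccc(F)c3)cc21`: 240 nM
Compound 3 `CC(Sc1nc2c(cnn2C)c(=O)n1-c1ccccc1)c1ccccn1`: 242 nM

Of the compounds shown here, three sharing the same bicyclic core have been tested in an assay on isolated protein for inhibition of aldehyde dehydrogenase 1A1 (Homo sapiens); a lower number here means a stronger inhibitor, a higher number a weaker inhibitor. Compound 3 stands second highest of the three numbers; its nearest neighbour is compound 2, whose value is within the scatter of that of compound 3, and its furthest is compound 1, whose value is also within the scatter. So the three measured compounds cannot be ordered against each other on the numbers shown.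

Compound 4 `CC(Sc1nc2c(cnn2C)c(=O)n1-c1ccccc1)c1cccc(O)c1` has not yet been measured in this assay. It differs from compound 3 in one place: 3-hydroxyphenyl in place of pyridin-2-yl on a saturated chain carbon bound to a saturated chain carbon and a sulfur. Going by the values given here, no pair of measured compounds differs in only this one place, so the size of this step has no direct precedent among the three. Given that the varied side groups in compounds 1, 2 and 3 all land within the scatter of one another in this assay, the step from compound 3 to compound 4 is expected to be small, with no direction beyond the scatter: a 1.0-fold higher number from compound 3 to compound 4 (0.01 log units; within the scatter). Compound 4 is accordingly estimated at 250 nM, within a range from 100 nM to 650 nM.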

Compound 4, half-maximal inhibitory concentration in the aldehyde dehydrogenase 1A1 assay: 130 nM
For compound 4 the middle estimate is 1.9-fold (0.28 log units) above the measured one; measured number inside the range.
By their numbers in the aldehyde dehydrogenase 1A1 assay, from the lowest: compounds 4, 2, 3 and 1 (each within the scatter of the next, the first and the last beyond it).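

On the saturated chain carbon bound to a saturated chain carbon and a sulfur, the series now has its first one-place comparison: with 3-hydroxyphenyl in place of pyridin-2-yl, the aldehyde dehydrogenase 1A1 assay gives a 1.9-fold lower number from compound 3 to compound 4 (0.27 log units; within the scatter), so a carbon-only ring carrying a hydrogen-bond donor and a ring holding one nitrogen without a donor cannot be told apart at this position. The same change in a physicochemical assay for solubility, using the shake flask method, in phosphate buffer, with a stated time of 24 h, at pH 7.4 (on this read-out higher numbers stand for higher solubility and lower numbers for lower solubility), gives a 1.1-fold higher number from compound 3 to compound 4 (0.02 log units; within the scatter), with compound 3 at 20000 nM and compound 4 at 21000 nM, so neither read-out separates the two compounds. Nothing among the data shown offers an explanation for either result.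

The compounds shown leave open whether the hydroxyl itself contributes anything at this position, as no pair sets 3-hydroxyphenyl against 3-methoxyphenyl or 3-aminophenyl on this carbon. They also leave open how far this position tolerates change, as a carboxylic acid on the ring or a longer chain in place of the ring does not appear among them.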